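A few compounds are considered here, and "the series" means these few. Any claim that something is new, unique, unknown or untested is made for them only; others in the source may bear on it.

Measured in an assay on isolated protein for binding affinity to 5-hydroxytryptamine receptor 6 (Homo sapiens); on this read-out higher numbers stand for weaker inhibition and lower numbers for stronger inhibition:
- compound 1 `c1ccc(-c2n[nH]cc2N2CCCNCC2)cc1`: 3480 nM
- compound 2 `COc1cccc(-c2n[nH]cc2N2CCNCC2)c1`: 269 nM
- compound 3 `Clc1ccc(-c2n[nH]cc2N2CCNCC2)cc1`: 75 nM

In this assay compound 2 stands second highest of the three numbers. Compound 3 gives a lower number than compound 2, a gap beyond the scatter, while compound 1 gives a higher number than compound 2, also beyond the scatter. The next compound, compound 4 `Fc1cccc(-c2n[nH]cc2N2CCNCC2)c1`, is not yet measured. Against compound 2 it carries fluoro in place of methoxy on an aromatic carbon. Within the data shown here, no measured pair in the set reproduces this change, so the size of the step rests on expectation alone: the step of a 1.3-fold lower number from compound 2 to compound 4 (0.13 log units; within the scatter) is expected to be small, toward a lower number if anything, and may well fall within the scatter. Compound 4 is therefore estimated at 200 nM, with a range from 60 nM to 700 nM.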

Compound 4, inhibition constant: 162 nM
Compound 4: the middle estimate sits 1.2-fold (0.09 log units) above what was measured; the measured number falls inside the stated range.
By their numbers in this assay, from the lowest: compound 3; then compounds 4 and 2 (each within the scatter of the next); then compound 1.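

In this assay, the aromatic carbon meta to a large group accepts fluoro in place of methoxy with a 1.7-fold lower number from compound 2 to compound 4 (0.22 log units; within the scatter), so this step stays within the scatter. The change removes a carbon, an oxygen and the hydrogen-bond acceptor counted for methoxy, and the two compounds still cannot be told apart on this read-out. Nothing at hand accounts for this result.

Open, as far as these compounds go, is how a larger or charged group, such as an amine or a carboxylic acid, would fare on this same carbon. Also open, from the compounds shown here alone, is whether the same fluoro-for-methoxy step would hold on the core of compound 1.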